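The source may hold more compounds than are shown below. What is called first, only, known or untested is meant among the compounds shown, and "the series" means these compounds.

Measured so far, in a functional assay on SMMC-7721 cells (Homo sapiens) for cytotoxicity, read by MTT assay, with a stated time of 4 days; a higher number here means a weaker inhibitor, a lower number a stronger inhibitor:

Compound 1 `C=C1C[C@]23C[C@@]1(O)CC[C@H]2c1ccc(O)c(C)c1[C@@H]3Cn1cc(-c2ccccn2)nn1` gives > 20000 nM. This is a limit of the assay, not a number.
Compound 2 `C=C1C[C@]23C[C@@]1(O)CC[C@H]2c1ccc(O)c(C)c1[C@@H]3Cn1cc(-c2ccc(Br)cc2)nn1` gives > 20000 nM. This too is a limit.
Compound 3 `C=C1C[C@]23C[C@@]1(O)CC[C@@H]2c1cccc(C)c1[C@@H]3Cn1cc(-c2ccc(Br)cc2)nn1` gives > 20000 nM. Again this is a limit.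

All three measured compounds sit at the same point, (the limit of > 20000 nM in this assay, at which 3 of the 3 values shown sit), so none of them can be called stronger or weaker than another, and none shows any measurable cell killing within the range the assay covers.

The change from compound 2 to compound 1 is pyridin-2-yl in place of 4-bromophenyl on an aromatic carbon. Its step, a step that the two limits leave unreadable from compound 2 to compound 1, cannot be given a size, since both ends rest on a limit rather than on a number. Compound 4 `C=C1C[C@]23C[C@@]1(O)CC[C@@H]2c1cccc(C)c1[C@@H]3Cn1cc(-c2ccccn2)nn1` carries the same change relative to compound 3: pyridin-2-yl in place of 4-bromophenyl on an aromatic carbon. The two descriptions of the place agree word for word, so this is the same change, not merely the same kind. How the core of compound 3 differs from the core of compound 2 is not broken down here.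

For compound 4 the expected step is a step that the limit leaves unreadable from compound 3 to compound 4, that is, essentially no readable movement. This expectation rests on compound 3 standing at > 20000 nM and on compound 1, the closest measured relative carrying the pyridin-2-yl group, standing at > 20000 nM. Compound 4 is therefore expected near 40000 nM, between 15000 nM and 200000 nM, most likely reported as a limit once more.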

Compound 4, half-maximal inhibitory concentration: > 20000 nM
Compound 4: a limit, no number (the forecaster's own chance of this, stated with the estimate: 85%); the middle value lies beyond the limit too.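

In this assay compound 4 gives > 20000 nM, which is a limit and not a number. Compound 3 rests on a limit as well, so no size can be read for the change from compound 3 to compound 4: the limit of > 20000 nM in this assay, at which 4 of the 4 values shown sit.

The compounds shown leave open whether replacing 4-bromophenyl with pyridin-2-yl, or the difference between the two cores, alters cell killing at all.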